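The source may hold more compounds than are shown below. What is called first, only, known or untested is meant among the compounds shown, and "the series" means these compounds.

The compounds here share one core, shown by compound 1 `CC(C)N(Cc1cccc(OCCCCCC(=O)O)c1)C(=O)c1ccccc1`. Compound 2 `CC(C)N(Cc1cccc(OCCCCCC(=O)O)c1)C(=O)c1ccc(-c2ccc(Cl)c(Cl)c2)cc1` adds a 3,4-dichlorophenyl group on an aromatic carbon, and compound 3 `CCOC(=O)CCCCCOc1cccc(CN(C(=O)c2ccccc2)C(C)C)c1` carries an ethyl on the oxygen next to the carbonyl group instead of a hydrogen. All three were tested in an ADME assay on BJ cells (Homo sapiens) for cytotoxicity, read by CellTiter-Glo and resazurin assay, with a stated time of 72 h; a higher number here means that more compound is needed for the effect, a lower number that less compound is needed. In this assay compound 1 gives > 26000 nM, which is a limit of the assay rather than a number. Compound 2 likewise gives > 26000 nM in this assay, again a limit. In this assay compound 3 also gives > 26000 nM, once more a limit. Compound 3 therefore stands where every measured compound stands, at the limit of > 26000 nM in this assay, at which 3 of the 3 values shown sit, with no number that would set it apart from the others.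

Compound 4 `CCOC(=O)CCCCCOc1cccc(CN(C(=O)c2ccc(-c3ccc(C(C)=O)s3)cc2)C(C)C)c1` keeps the ester of compound 3 and differs from it in one place: 5-acetylthiophen-2-yl in place of hydrogen on an aromatic carbon. For the measured compounds named here, two measured steps bear on this. The step that the two limits leave unreadable from compound 1 to compound 2 also placed an aromatic group on an aromatic carbon, and the step that the two limits leave unreadable from compound 1 to compound 3 introduced the ethyl ester; neither has a readable size, since both of their ends sit at the limit. The expected step that the limit leaves unreadable from compound 3 to compound 4 is thus no larger than the scatter, with the most likely outcome being that the assay once more reports only a limit. Compound 4 is estimated at 30000 nM, within a range from 10000 nM to 100000 nM.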

Compound 4, half-maximal effective concentration: > 26000 nM
Compound 4: a limit, no number; the forecaster's own chance of this, stated with the estimate: 70%; the middle value lies beyond the limit too.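

In this assay compound 4 gives > 26000 nM, which is a limit and not a number. Its step from compound 3 cannot be read, since both compounds sit at a limit. The compounds shown leave open what concentration of any of them produces the effect, and whether any of these changes alters it, because all results coincide: the limit of > 26000 nM in this assay, at which 4 of the 4 values shown sit.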